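Tetrazole tail in place of a nitrile tail

This account rests on a few compounds, and the source may have more. Where it says the series, first, only, none or still open, it means among the compounds named here.

Compound 2 `CCc1cc(C(C)=O)c(O)cc1OCCCCCC(C)(C)C#N` is the starting point. In an assay on isolated protein for inhibition of leukotriene B4 receptor 1 (Homo sapiens), tested at 10 uM (on this read-out lower numbers stand for less inhibition and higher numbers for more inhibition at the one concentration tested (going by the name of the read-out)), compound 2 gives 85%, the second highest of three numbers. Compound 1 `C=CCc1cc(C(C)=O)c(O)cc1OCCCCCCCCC#N` gives 86%, within the scatter of compound 2. For the measured compounds named here, compound 3 `CC(=O)c1cc(C(C)(C)C)c(OCCCCCC(C)(C)C#N)cc1O` gives 1%, and the one measured step, a number 84 percentage points lower from compound 2 to compound 3 (beyond the scatter), comes from tert-butyl in place of ethyl on an aromatic carbon. Compound 4 `CCc1cc(C(C)=O)c(O)cc1OCCCCc1nnn[nH]1` differs from compound 2 at the other end of the molecule: 1H-tetrazol-5-yl in place of 2-cyano-2-methylpropyl on a saturated chain carbon, four bonds along the chain from an oxygen on an aromatic ring. Going by the values given here, no measured step touches this chain end; both compounds that carry a nitrile tail, compound 1 and compound 2, sit at much the same high level, while the step from compound 2 to compound 3 concerns the aromatic carbon and does not bear on the tail. With nothing to show that the tail governs the read-out, he expects compound 4 to stay near compound 2, with an expected step of a number 13 percentage points lower from compound 2 to compound 4 (beyond the scatter) and the uncertainty of an untested change. His estimate for compound 4 in this assay is 72%, between 35% and 95%.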

Compound 4, a percentage reported as inhibition, at one concentration (the size of the read-out at that concentration, not a potency): 49%
Beside the measured number, compound 4's estimate is 23 percentage points above it; measured number inside the range.
By their numbers in this assay, from the lowest: compound 3; then compound 4; then compounds 2 and 1 (each within the scatter of the next).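

In this assay, the chain end four bonds along from the oxygen on the aromatic ring proves sensitive to change: 1H-tetrazol-5-yl in place of 2-cyano-2-methylpropyl gives a number 36 percentage points lower from compound 2 to compound 4 (beyond the scatter). The nitrile is nevertheless not needed for all inhibition at this concentration, as compound 4 , which has none, still gives 49%. Nothing available bears on the reason for this drop.

The change removes the whole 2-cyano-2-methylpropyl group, so the compounds shown do not separate the effect of the entering ring from that of the chain atoms and nitrile that leave. A carboxylic acid at this place, or 1H-tetrazol-5-yl carried on a longer chain, would help to pull these apart.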